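Swapping chloro for methyl on a scaffold with no measured toxicity

A few compounds are considered here, and "the series" means these few. Any claim that something is new, unique, unknown or untested is made for them only; others in the source may bear on it.

Measured so far:
- Compound 1, `CCCC(=O)Nc1ncc(-c2ccc(OC)cc2)n1C`: > 100000 nM
- Compound 2, `COc1ccc(-c2cnc(NC(=O)c3cnco3)n2C)cc1`: > 100000 nM
- Compound 3, `COc1ccc(-c2cnc(NC(=O)c3ccc(Cl)cc3)n2C)cc1`: > 100000 nM

The three measured compounds share a core and differ only in the group on the carbonyl carbon. In a toxicity assay on THP-1 cells (Homo sapiens) for inhibition (on this read-out higher numbers stand for lower toxicity in this test and lower numbers for higher toxicity in this test), compound 1 reaches only a limit, > 100000 nM. In this assay compound 2 likewise reaches only a limit, > 100000 nM. Compound 3 also sits at a limit, > 100000 nM. Because all three values stop at the same limit, (the limit of > 100000 nM in this assay, at which 3 of the 3 values shown sit), none of the steps between them can be read: a step that the two limits leave unreadable from compound 1 to compound 2, a step that the two limits leave unreadable from compound 1 to compound 3 and a step that the two limits leave unreadable from compound 2 to compound 3 give no size and no direction.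

Compound 4, `COc1ccc(-c2cnc(NC(=O)c3ccc(C)cc3)n2C)cc1`, is not yet measured. It differs from compound 3 by methyl in place of chloro on an aromatic carbon. Going by the values given here, no measured step bears on this change, since every step available is hidden by the limit, so no size and no direction can be drawn from them. What the data do show is that each measured group on the carbonyl carbon leaves this assay at its limit, which makes it reasonable to expect compound 4 there too. The expected step is a step that the limit leaves unreadable from compound 3 to compound 4, no larger than the usual scatter. Compound 4 is therefore estimated at 150000 nM, with a range from 100000 nM to 300000 nM, most likely reported as a limit again.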

Compound 4, half-maximal cytotoxic concentration: > 100000 nM
Compound 4 ended at the assay's limit; the forecaster's own chance of this, stated with the estimate: 85%; the middle value does not contradict the limit.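

Compound 4 sits at a limit in this assay, as do compound 1, compound 2 and compound 3, so no step among these four compounds can be read for size or direction: the limit of > 100000 nM in this assay, at which 4 of the 4 values shown sit.

The compounds shown leave open whether any change to the group on the carbonyl carbon would give a value that this assay can actually read as a number.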